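The source may hold more compounds than are shown below. What is called first, only, known or untested is meant among the compounds shown, and "the series" means these compounds.

Compound 1 `CCCC(=O)N1CC2CC(C1)N2` carries a propyl chain on the carbonyl carbon of the shared core. Among the measured compounds shown here, in an assay on SH-EP1 cells for agonist activity at Neuronal acetylcholine receptor; alpha4/beta2 (Homo sapiens), read by FLIPR and calcium flux (on this read-out higher numbers stand for an effect only at larger amounts of compound and lower numbers for an effect already at smaller amounts), compound 1 gives 580 nM, which is the second highest of the three numbers measured so far. Two relatives replace that chain with a 2-fluorocyclopropyl ring: compound 2 `O=C([C@@H]1C[C@@H]1F)N1CC2CC(C1)N2` gives 120 nM, and compound 3 `O=C([C@H]1C[C@@H]1F)N1CC2CC(C1)N2` gives 850 nM. So a 4.8-fold lower number from compound 1 to compound 2 (0.68 log units; beyond the scatter), whereas a 1.5-fold higher number from compound 1 to compound 3 (0.17 log units; within the scatter). Between the two ring compounds, a 7.1-fold higher number from compound 2 to compound 3 (0.85 log units; beyond the scatter); the pair share every atom and bond and part only at one stereocentre, a point noted by the fact that one of compounds 2 and 3 is drawn with a defined configuration and the other without, at the place where they differ.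

Compound 4 `C[C@@H]1C[C@H]1C(=O)N1CC2CC(C1)N2` is the next compound to be tested. (2-methylcyclopropyl in place of propyl on a carbonyl carbon). The new ring has the same size as the ring in compounds 2 and 3, but carries a methyl group where they carry fluorine, and both of its stereocentres are defined. The two measured steps that bear on this change disagree: one ring arrangement brought a modest gain over compound 1, the other brought no step beyond the scatter. A small gain is therefore expected, with wide uncertainty, so that a 1.7-fold lower number from compound 1 to compound 4 (0.22 log units; within the scatter). The estimate for compound 4 is 350 nM, within a range from 100 nM to 1200 nM.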

Compound 4, half-maximal effective concentration: 190 nM
For compound 4 the middle estimate is 1.8-fold (0.27 log units) above the measured one; measured number inside the range.
By their numbers in this assay, from the lowest: compounds 2 and 4 (each within the scatter of the next); then compounds 1 and 3 (each within the scatter of the next).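

In this assay the propyl chain on the carbonyl carbon can give way to a ring carrying methyl as well as to one carrying fluorine, with a 3.1-fold lower number from compound 1 to compound 4 (0.48 log units; beyond the scatter). Compounds 2 and 4 now both lie on the lower side of compound 1, and compound 3 goes against this pattern; the methyl ring also separates from the less favourable fluorine ring, with a 4.5-fold lower number from compound 3 to compound 4 (0.65 log units; beyond the scatter), yet it cannot be told apart from the better fluorine ring, with a 1.6-fold higher number from compound 2 to compound 4 (0.20 log units; within the scatter). So among the rings shown, exchanging fluorine for methyl does not by itself settle the number, and no information given here explains why compound 3 stands apart from compounds 2 and 4.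

The compounds shown leave open how the other stereo arrangements of the 2-methylcyclopropyl ring would behave, given how far compounds 2 and 3 part with a single stereocentre changed. They also leave open whether an amine or a longer chain on the ring in place of methyl would keep a number like that of compound 4.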